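Compound 4 and the 4-bromophenyl exchange

A few compounds are considered here, and "the series" means these few. Any claim that something is new, unique, unknown or untested is made for them only; others in the source may bear on it.

Compound 3 (`CC(C)(C)OC(=O)N1C[C@@H](n2cc(-c3ccc4nc(N)sc4n3)nn2)C[C@H]1C(=O)Nc1ccc(Cl)c(C(F)(F)F)c1`) reads 10900 nM in a functional assay on K562 cells (Homo sapiens) for inhibition, read by MTT assay, with a stated time of 48 h (on this read-out lower numbers stand for stronger inhibition and higher numbers for weaker inhibition), and stands level, within the scatter, with compound 1 (`CC(C)(C)OC(=O)N1C[C@@H](n2cc(-c3ccc4c(N)n[nH]c4c3)nn2)C[C@H]1C(=O)Nc1ccc(Cl)c(C(F)(F)F)c1`) at 10500 nM while compound 2 (`CC(C)(C)OC(=O)N1C[C@@H](n2cc(-c3ccc4c(N)n[nH]c4c3)nn2)C[C@H]1C(=O)Nc1ccc(Br)cc1`) at 3710 nM carries the lowest number of the three. Compound 4 (`CC(C)(C)OC(=O)N1C[C@@H](n2cc(-c3ccc4nc(N)sc4n3)nn2)C[C@H]1C(=O)Nc1ccc(Br)cc1`) differs from compound 3 by a single exchange on an amide-type nitrogen, 4-bromophenyl in place of 4-chloro-3-(trifluoromethyl)phenyl (4-bromophenyl in place of 4-chloro-3-(trifluoromethyl)phenyl on an amide-type nitrogen). The same exchange has been measured once, as a 2.8-fold lower number from compound 1 to compound 2 (0.45 log units; beyond the scatter) and this modest step lies beyond the scatter. The other measured step, a 1.0-fold higher number from compound 1 to compound 3 (0.02 log units; within the scatter) is the one that links the two cores, and it lies within the scatter. Whether the exchange carries over to the core of compound 3 has not been shown, but a step of similar size is expected. Resting on that single pair, the expected step is a 2.7-fold lower number from compound 3 to compound 4 (0.42 log units; beyond the scatter) toward a lower number in this assay as estimated here. For compound 4 the expected value is 4100 nM with an estimated range from 2000 nM to 8500 nM in this read-out.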

Compound 4, half-maximal inhibitory concentration: 29200 nM
Estimate against measurement, compound 4: 7.1-fold (0.85 log units) below; measured number outside the range, above it.
By their numbers in this assay, from the lowest: compound 2; then compounds 1 and 3 (each within the scatter of the next); then compound 4.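

In this assay, the exchange of 4-chloro-3-(trifluoromethyl)phenyl for 4-bromophenyl on the amide-type nitrogen has no fixed direction. On the second core it gives a 2.7-fold higher number from compound 3 to compound 4 (0.43 log units; beyond the scatter), so its outcome differs with the core that carries it: the same change on two cores in this assay, a 2.8-fold lower number (0.45 log units; beyond the scatter) from compound 1 to compound 2 and a 2.7-fold higher number (0.43 log units; beyond the scatter) from compound 3 to compound 4, 7.6-fold (0.88 log units) apart, beyond the scatter of two such steps. The two cores cannot be told apart with 4-chloro-3-(trifluoromethyl)phenyl on this nitrogen, but they separate with 4-bromophenyl there, giving a 7.9-fold higher number from compound 2 to compound 4 (0.90 log units; beyond the scatter): the same change on two cores in this assay, a 1.0-fold higher number (0.02 log units; within the scatter) from compound 1 to compound 3 and a 7.9-fold higher number (0.90 log units; beyond the scatter) from compound 2 to compound 4, 7.6-fold (0.88 log units) apart, beyond the scatter of two such steps.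

The compounds shown change the halogen and the trifluoromethyl group together, so they leave open which part of the exchange accounts for the opposite steps. A 4-chlorophenyl or a 3-(trifluoromethyl)phenyl group on the same nitrogen of each core would separate the two parts, and each direction still rests on a single pair.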